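The compounds below may be only part of what the source reports. "The series", "measured", "known", "first", "only" and "open" are said of these compounds alone.

Of the compounds shown here, two have been measured in a toxicity assay on L02 cells (Homo sapiens) for cytotoxicity, read by MTT assay, with a stated time of 72 h; a lower number here means a stronger inhibitor, a higher number a weaker inhibitor. Compound 1 `O=C1c2c[n+]([O-])c3ccccc3c2C(=O)c2c1c1ccccc1n2Cc1cn([C@@H]2C[C@H](O)[C@@H](CO)O2)nn1` gives 630 nM. Compound 2 `CC1(C)O[C@@H](CO)[C@H](Cn2cc(Cn3c4c(c5ccccc53)C(=O)c3c[n+]([O-])c5ccccc5c3C4=O)nn2)O1` gives 500 nM, which is the lowest of the two numbers, though the step of a 1.3-fold lower number from compound 1 to compound 2 (0.10 log units; within the scatter) lies within the scatter, so the two values cannot be told apart.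

Compound 3 `O=C1c2c[n+]([O-])c3ccccc3c2C(=O)c2c1c1ccccc1n2Cc1cn([C@H]2C[C@H](O)[C@@H](CO)O2)nn1` is the next compound to be tested. Its change from compound 2 is 4-hydroxy-5-(hydroxymethyl)oxolan-2-yl in place of (5-(hydroxymethyl)-2,2-dimethyl-1,3-dioxolan-4-yl)methyl on an aromatic nitrogen. This returns the same kind of sugar group that compound 1 carries, differing from compound 1 only in the arrangement at one stereocentre.

For the measured compounds named here, the only step that bears on this change is the one from compound 1 to compound 2, and it was small, a 1.3-fold lower number from compound 1 to compound 2 (0.10 log units; within the scatter). Going back to the sugar ring is therefore expected to move the number little, if at all, beyond the scatter. Compound 3 is expected to give 600 nM, with a range from 300 nM to 1200 nM. The estimated step is a 1.2-fold higher number from compound 2 to compound 3 (0.08 log units; within the scatter).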

Compound 3, half-maximal inhibitory concentration: 280 nM
The estimate for compound 3 lay 2.1-fold (0.33 log units) above the measured number; measured number outside the range, below it.
By their numbers in this assay, from the lowest: compounds 3, 2 and 1 (each within the scatter of the next, the first and the last beyond it).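

For the compounds shown here, the first step in this assay to pass the scatter is a 2.3-fold lower number from compound 1 to compound 3 (0.35 log units; beyond the scatter), modest in size, and it neither adds nor removes any atoms. The gap can be tied to the single stereocentre at a saturated ring carbon, drawn S in compound 1 and R in compound 3, because of one fact: the fact that compounds 1 and 3 differ only in the configuration as drawn. By contrast, a 1.8-fold lower number from compound 2 to compound 3 (0.25 log units; within the scatter) stays within the scatter, so exchanging the (5-(hydroxymethyl)-2,2-dimethyl-1,3-dioxolan-4-yl)methyl group for the 4-hydroxy-5-(hydroxymethyl)oxolan-2-yl group on this aromatic nitrogen has no readable effect here.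

A single pair cannot show whether the preference for one arrangement would carry over to other groups on this nitrogen. The compounds shown also leave open what would happen with an amine or a methoxy group in place of a ring hydroxyl.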